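The source may report more compounds than this note shows. Statements on the series, on what has been measured and on what is new or still open speak of the compounds shown alone.

Compound 3 `COc1ccc(F)cc1CNCCCNc1ccnc2cc(Cc3ccc(F)cc3)ccc12` gives 3530 nM in an ADME assay on HepG2 cells (Homo sapiens) for cytotoxicity, read by luminescence, CellTiter-Glo and ATP content, with a stated time of 72 h (a higher number here means that more compound is needed for the effect, a lower number that less compound is needed), the second highest of the three numbers. Compound 1 `COc1ccc(F)cc1CNCCCNc1ccnc2cc(Cc3cc(C)cc(C)c3)ccc12` gives 940 nM, the lowest, and compound 2 `Fc1ccc(-c2ccc3c(NCCCNCc4ccco4)ccnc3c2)cc1` gives 7760 nM, the highest of the set. Within the data shown here, the only single-point step measured, a 3.8-fold higher number from compound 1 to compound 3 (0.57 log units; beyond the scatter), concerns a ring swap on the same saturated chain carbon and does not test the change now at hand. Compound 4 `COc1ccc(F)cc1CNCCCNc1ccnc2cc(-c3ccc(F)cc3)ccc12` differs from compound 3 by 4-fluorophenyl in place of 4-fluorobenzyl on an aromatic carbon. Compound 2 also carries a 4-fluorophenyl on an aromatic carbon and its number sits above that of compound 3, but the two differ elsewhere as well, so this is only a hint. For compound 4 a step no larger than the scatter is expected, a 1.4-fold higher number from compound 3 to compound 4 (0.15 log units; within the scatter), leaning toward a higher number. Compound 4 is therefore estimated at 5000 nM, within 1500 nM to 15000 nM.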

Compound 4, half-maximal effective concentration: 770 nM
Compound 4: the middle estimate sits 6.5-fold (0.81 log units) above what was measured; measured number below the stated range.
By their numbers in this assay, from the lowest: compounds 4 and 1 (each within the scatter of the next); then compound 3; then compound 2.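

In this assay, the aromatic carbon of the shared core responds to the linking carbon: 4-fluorophenyl in place of 4-fluorobenzyl gives a 4.6-fold lower number from compound 3 to compound 4 (0.66 log units; beyond the scatter). With 4-fluorophenyl on that carbon, the saturated chain carbon bound to an amine nitrogen also counts, as 5-fluoro-2-methoxyphenyl in place of furan-2-yl gives a 10-fold lower number from compound 2 to compound 4 (1.00 log units; beyond the scatter). Direct 4-fluorophenyl and 3,5-dimethylbenzyl are not separated, with a 1.2-fold lower number from compound 1 to compound 4 (0.09 log units; within the scatter). No measurement at hand accounts for these steps. Open, on these data alone, is how 3,5-dimethylphenyl directly on the aromatic carbon, or an ethylene link there, would read.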